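Swapping the amide group: compound 2 to compound 3

The compounds below may be only part of what the source reports. "The series", "measured", "known", "first", "only" and "open" are said of these compounds alone.

In an ADME assay on LLC-MK2 cells (Macaca mulatta) for cytotoxicity, read by spectrophotometry and crystal violet staining, with a stated time of 4 days (on this read-out lower numbers stand for higher toxicity in this test and higher numbers for lower toxicity in this test), compound 1 `CC(C)n1ncc2c(C(=O)Nc3cncnc3)cc(-c3cccs3)nc21` gives 20000 nM and compound 2 `CC(C)n1ncc2c(C(=O)Nc3cc(C(N)=O)ccc3F)cc(-c3cccs3)nc21` gives 25000 nM, two values within the scatter of each other. Compound 3 `CC(C)n1ncc2c(C(=O)Nc3ccncn3)cc(-c3cccs3)nc21` has pyrimidin-4-yl in place of 5-carbamoyl-2-fluorophenyl on an amide-type nitrogen. Among the compounds with values here, the only measured step, a 1.3-fold higher number from compound 1 to compound 2 (0.10 log units; within the scatter), exchanges the same two kinds of group at that place and stays within the scatter. The estimated step is a 1.1-fold lower number from compound 2 to compound 3 (0.06 log units; within the scatter), so no change beyond the scatter is expected in this assay. For compound 3 the expected value is 22000 nM, with an estimated range of 10000 nM to 50000 nM.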

Compound 3, half-maximal cytotoxic concentration: 50000 nM
For compound 3 the middle estimate is 2.3-fold (0.36 log units) below the measured one; measured number inside the range.
By their numbers in this assay, from the lowest: compounds 1, 2 and 3 (each within the scatter of the next, the first and the last beyond it).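

In this assay, the amide-type nitrogen now shows its first step beyond the scatter, a 2.5-fold higher number from compound 1 to compound 3 (0.40 log units; beyond the scatter), a modest step made by pyrimidin-4-yl in place of pyrimidin-5-yl. The two pyrimidinyl groups can therefore be told apart at this place, whereas 5-carbamoyl-2-fluorophenyl separates from neither: a 2.0-fold higher number from compound 2 to compound 3 (0.30 log units; within the scatter), like the earlier step from compound 1 to compound 2, stays within the scatter. No supporting data bear on why the pyrimidinyl groups differ.

Open, as far as these compounds go, is how a basic amine or a carboxylic acid on the amide-type nitrogen would read here, and whether a longer chain at that place would move the number further.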